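The source may hold more compounds than are shown below. What is called first, only, known or untested is meant among the compounds shown, and "the series" means these compounds.

Compound 1 `COc1ccc(S(=O)(=O)N2CCc3cccc(-c4ccc(N)cc4)c32)cc1` gives 249 nM in a functional assay on KB cells (Homo sapiens) for inhibition, with a stated time of 72 h; a lower number here means a stronger inhibitor, a higher number a weaker inhibitor.
Compound 2 `COc1ccc(S(=O)(=O)N2CCc3cccc(-c4ccc(N(C)C)cc4)c32)cc1` gives 539 nM in this assay.
Compound 3 `COc1ccc(S(=O)(=O)N2CCc3cccc(-c4ccc(F)cc4)c32)cc1` gives 86 nM in this assay.

Compound 3 has the lowest number of the three, and its steps to the others, a 2.9-fold lower number from compound 1 to compound 3 (0.46 log units; beyond the scatter) and a 6.3-fold lower number from compound 2 to compound 3 (0.80 log units; beyond the scatter), both lie beyond the scatter. Compound 4 `COc1ccc(S(=O)(=O)N2CCc3cccc(-c4ccc(C#N)cc4)c32)cc1` differs from compound 3 by cyano in place of fluoro on an aromatic carbon. The measured steps that bear on this change are the three swaps of the group on an aromatic carbon para to a large group: a 2.2-fold higher number from compound 1 to compound 2 (0.34 log units; beyond the scatter), a 2.9-fold lower number from compound 1 to compound 3 (0.46 log units; beyond the scatter) and a 6.3-fold lower number from compound 2 to compound 3 (0.80 log units; beyond the scatter), all of modest size. Among the measured compounds shown here, no measured step in this assay compares cyano with fluoro directly, so a step of at most modest size in either direction is expected. Compound 4 is therefore estimated at 120 nM, within 40 nM to 400 nM, an expected step of a 1.4-fold higher number from compound 3 to compound 4 (0.14 log units; within the scatter).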

Compound 4, half-maximal inhibitory concentration: 31.1 nM
Beside the measured number, compound 4's estimate is 3.9-fold (0.59 log units) above it; measured number outside the range, below it.
By their numbers in this assay, from the lowest: compound 4; then compound 3; then compound 1; then compound 2.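

In this assay, cyano in place of fluoro on this aromatic carbon gives a 2.8-fold lower number from compound 3 to compound 4 (0.44 log units; beyond the scatter), so fluoro did not mark the lowest number this position can reach. Against the two amino groups, cyano gives an 8.0-fold lower number from compound 1 to compound 4 (0.90 log units; beyond the scatter) and a 17-fold lower number from compound 2 to compound 4 (1.24 log units; beyond the scatter), and the latter is the only large step in the series. No measurement shown accounts for this order among the four groups. From the compounds shown here alone, it remains open whether trifluoromethyl, a carboxylic acid or an amide on this carbon would give a number lower than that of compound 4.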